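This account rests on a few compounds, and the source may have more. Where it says the series, first, only, none or still open, it means among the compounds named here.

The measured compounds:

compound 1, `Cc1ccc(-n2nccn2)c(C(=O)N2C[C@H](C#Cc3cccnc3)CC[C@H]2C)c1`, gives 41 nM in an assay on cells for binding affinity to Orexin receptor type 2 (Homo sapiens), read by radioligand binding; a higher number here means a weaker inhibitor, a lower number a stronger inhibitor
compound 2, `Cc1ccc(-n2nccn2)c(C(=O)N2C[C@H](C#Cc3ccc(CO)cn3)CC[C@H]2C)c1`, gives 130 nM in this assay
compound 3, `Cc1ccc(-n2nccn2)c(C(=O)N2C[C@H](C#Cc3cncc(CO)c3)CC[C@H]2C)c1`, gives 32 nM in this assay

Compound 2 stands at the highest of these three numbers. Its nearest neighbour is a 3.2-fold higher number from compound 1 to compound 2 (0.50 log units; beyond the scatter), and the furthest is a 4.1-fold lower number from compound 2 to compound 3 (0.61 log units; beyond the scatter). The third comparison, a 1.3-fold lower number from compound 1 to compound 3 (0.11 log units; within the scatter), shows that adding the hydroxymethyl to the pyridin-3-yl changes little.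

Compound 4, `Cc1ccc(-n2nccn2)c(C(=O)N2C[C@H](/C=C\c3ccc(F)cn3)CC[C@H]2C)c1`, has not yet been measured in this assay. Compared with compound 2, the change is 2-(5-fluoropyridin-2-yl)ethenyl in place of 2-(5-(hydroxymethyl)pyridin-2-yl)ethynyl on a saturated ring carbon. The two steps beyond the scatter both concern where the pyridine is attached, and compound 4 keeps the pyridin-2-yl attachment of compound 2. Nothing measured speaks to the change from a triple bond to a double bond or to the fluorine in place of the hydroxymethyl, so the direction of the step is open. On that basis compound 4 is expected to land near compound 2, with a wide range around it. The step expected is a 1.3-fold lower number from compound 2 to compound 4 (0.11 log units; within the scatter). The estimate for compound 4 in this assay is 100 nM, between 25 nM and 400 nM.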

Compound 4, inhibition constant: 28 nM
Beside the measured number, compound 4's estimate is 3.6-fold (0.55 log units) above it; measured number inside the range.
By their numbers in this assay, from the lowest: compounds 4, 3 and 1 (each within the scatter of the next); then compound 2.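

In this assay, the pyridin-2-yl attachment does not by itself go with the weakest number, since compound 4 keeps that attachment and still shows a 4.6-fold lower number from compound 2 to compound 4 (0.67 log units; beyond the scatter). Against the two pyridin-3-yl compounds, compound 4 shows a 1.1-fold lower number from compound 3 to compound 4 (0.06 log units; within the scatter) and a 1.5-fold lower number from compound 1 to compound 4 (0.17 log units; within the scatter), so both steps leave it level with them even though the triple bond has given way to a double bond. The saturated ring carbon that carries these groups, two ring bonds from the ring nitrogen, therefore holds a 2-(5-fluoropyridin-2-yl)ethenyl group as well as it holds the ethynyl groups of compound 1 and compound 3.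

The step from compound 2 combines two changes, the double bond for the triple bond and fluorine for hydroxymethyl, and the compounds shown neither divide it between them nor offer any independent data that would explain it. Going by these compounds, it also remains open how this place would respond to a saturated two-carbon ethyl link to the pyridine, or to an aminomethyl group on the pyridine where compound 4 carries its fluorine.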